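The source may hold more compounds than are shown below. What is called first, only, known or untested is meant among the compounds shown, and "the series" means these compounds.

Measured in an ADME assay on BJ cells (Homo sapiens) for cytotoxicity, with a stated time of 72 h; on this read-out higher numbers stand for an effect only at larger amounts of compound and lower numbers for an effect already at smaller amounts:
- compound 1 `Cc1cc(NC(=O)Nc2ccc(C(C)(C)C)cc2)c2ccccc2n1`: 20000 nM
- compound 2 `Cc1cc(NC(=O)Nc2cccc(F)c2)c2ccccc2n1`: > 25000 nM (a limit of the assay)
- compound 3 `COC(=O)c1ccc(NC(=O)Nc2cc(C)nc3ccccc23)cc1`: 21000 nM

Among the compounds with values here, compound 3, at 21000 nM, stands level with compound 1 at 20000 nM, the only other compound with a number in this assay. For compound 2 the value > 25000 nM is a limit.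

The next compound is compound 4 `Cc1cc(NC(=O)Nc2ccc(N)cc2)c2ccccc2n1`, which carries amino in place of methoxycarbonyl on an aromatic carbon, para to a large group. The counted difference is amino in place of methoxycarbonyl on an aromatic carbon.

Within the data shown here, one measured step bears on this change: a 1.1-fold higher number from compound 1 to compound 3 (0.02 log units; within the scatter). It exchanges tert-butyl for methoxycarbonyl on an aromatic carbon, so it touches the group that now leaves, but amino itself has not been measured in this series. That single step is thin support, yet it gives no reason to expect a move in either direction. No step beyond the scatter is therefore expected in this assay.

The expected step is a 1.1-fold lower number from compound 3 to compound 4 (0.04 log units; within the scatter).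

For compound 4 the estimated value is 19000 nM, with an expected range from 9000 nM to 28000 nM.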

Compound 4, half-maximal effective concentration: > 25000 nM
Compound 4 gave a limit, no number; the forecaster's own chance of this, stated with the estimate: 30%; middle value at least 1.3-fold (0.11 log units) from the limit.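

In this assay, within the data shown here, compound 4 gives > 25000 nM, which is a limit of the assay and not a number; amino is thus the one group at this aromatic carbon, para to a large group, to end in a limit, whereas tert-butyl and methoxycarbonyl both gave numbers. Against those numbers the change reads as an at least 1.1-fold higher number from compound 3 to compound 4 (0.07 log units; that floor lies within the scatter) and as an at least 1.2-fold higher number from compound 1 to compound 4 (0.09 log units; that floor lies within the scatter); both floors lie within the scatter, so neither step establishes a real rise, and neither rules one out. The step between compound 2 and compound 4 cannot be read, and the full size of the other two steps stays unknown, because compound 4 stops at the same limit as compound 2: the limit of > 25000 nM in this assay, at which 2 of the 4 values shown sit.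

Open, as far as these compounds go, is whether amino itself sets compound 4 apart or whether other small groups at this carbon would behave alike, a question that a hydroxy group, a dimethylamino group or an acetamide could answer. Also open, from the compounds shown here alone, is what a carboxylic acid would give in place of the methoxycarbonyl of compound 3.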